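The compounds below may be only part of what the source reports. "The series", "measured", "known", "first", "only" and "open" are said of these compounds alone.

For the measured compounds named here, compound 1 `COc1cc2c(Oc3ccc(NC(=O)c4nnn(-c5ccccc5C)c4C)cc3F)ccnc2cc1OCCCN1CCCC1` is one of two compounds measured in a functional assay on NCI-H460 cells (Homo sapiens) for cytotoxicity, read by MTT assay, with a stated time of 72 h; a higher number here means a weaker inhibitor, a lower number a stronger inhibitor; in this assay compound 1 gives 720 nM, the higher of the two numbers. Compound 2 `COc1cc2c(Oc3ccc(NC(=O)c4nnn(-c5ccccc5)c4C)cc3F)ccnc2cc1OCCCN1CCCC1` gives 160 nM, and the step from compound 1 to compound 2 is a 4.5-fold lower number from compound 1 to compound 2 (0.65 log units; beyond the scatter). Compound 3 `COc1cc2c(Oc3ccc(NC(=O)c4nnn(-c5ccccc5C(F)(F)F)c4C)cc3F)ccnc2cc1OCCCN1CCCC1` differs from compound 1 by trifluoromethyl in place of methyl on an aromatic carbon. Going by the values given here, only the step from compound 1 to compound 2 touches this position, and it shows that a bare ring gives a lower number than methyl; nothing measured shows what trifluoromethyl does there, so the direction is uncertain. Compound 3 is therefore expected to show a 1.4-fold higher number from compound 1 to compound 3 (0.14 log units; within the scatter), an estimated 1000 nM with a range from 300 nM to 3500 nM.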

Compound 3, half-maximal inhibitory concentration: 230 nM
Estimate against measurement, compound 3: 4.3-fold (0.64 log units) above; the measured number lies below the stated range.
By their numbers in this assay, from the lowest: compounds 2 and 3 (each within the scatter of the next); then compound 1.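

Replacing methyl with trifluoromethyl at this place gives a 3.1-fold lower number from compound 1 to compound 3 (0.50 log units; beyond the scatter) in this assay, so the high number of compound 1 does not come with every group larger than hydrogen. Trifluoromethyl in place of hydrogen gives a 1.4-fold higher number from compound 2 to compound 3 (0.16 log units; within the scatter) and thus cannot be told apart from the bare ring here. Nothing available explains why methyl and trifluoromethyl differ.

Still open, from the compounds shown here alone, is whether a chlorine, a methoxy group or an amine at this place would stay level with compound 2 or move toward compound 1.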